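The source may report more compounds than this note shows. Statements on the series, on what has been measured and on what is new or still open speak of the compounds shown alone.

Measured so far in a functional assay on BCG823 cells (Homo sapiens) for inhibition, read by MTT assay, with a stated time of 72 h; a higher number here means a weaker inhibitor, a lower number a stronger inhibitor:

Compound 1, `Cc1nc(N(C)C(=O)NC(=O)c2c(F)cccc2F)sc1C(=O)N/N=C/c1cccc(C(F)(F)F)c1`: 32.7 ug/mL
Compound 2, `CN(C(=O)NC(=O)c1ccc(C(F)(F)F)cc1)c1nc(C(F)(F)F)c(C(=O)N/N=C/c2cccc(C(F)(F)F)c2)s1`: 1.84 ug/mL
Compound 3, `CN(C(=O)NC(=O)c1ccc(C(F)(F)F)cc1)c1nc(C(F)(F)F)c(C(=O)N/N=C/c2cc(C(F)(F)F)cc(C(F)(F)F)c2)s1`: 1.77 ug/mL

Of these three, compound 1 gives by far the highest number in this assay, while compound 2 and compound 3 sit close together. Compound 3 differs from compound 2 by a single change, (trifluoromethyl in place of hydrogen on an aromatic carbon), and that step came out as a 1.0-fold lower number from compound 2 to compound 3 (0.02 log units; within the scatter). The difference between the core of compound 1 and the core of compound 2 is not broken down here. Compound 4, `Cc1nc(N(C)C(=O)NC(=O)c2c(F)cccc2F)sc1C(=O)N/N=C/c1cc(C(F)(F)F)cc(C(F)(F)F)c1`, has not yet been measured in this assay; it differs from compound 1 by the same change, (trifluoromethyl in place of hydrogen on an aromatic carbon). Because the earlier step of a 1.0-fold lower number from compound 2 to compound 3 (0.02 log units; within the scatter) lay within the scatter, the step from compound 1 to compound 4 is likewise expected to be small, about a 1.1-fold lower number from compound 1 to compound 4 (0.04 log units; within the scatter). Compound 4 is therefore estimated to give roughly 30 ug/mL in this assay, most likely between 15 ug/mL and 60 ug/mL.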

Compound 4, half-maximal inhibitory concentration: 14.1 ug/mL
For compound 4 the middle estimate is 2.1-fold (0.33 log units) above the measured one; measured number below the stated range.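

In this assay, placing a trifluoromethyl on the aromatic ring of compound 1 gives a 2.3-fold lower number from compound 1 to compound 4 (0.37 log units; beyond the scatter), a modest step. The same change on the other core gives a step that does not differ from this one by more than the scatter of two such steps: the same change on two cores in this assay, a 1.0-fold lower number (0.02 log units; within the scatter) from compound 2 to compound 3 and a 2.3-fold lower number (0.37 log units; beyond the scatter) from compound 1 to compound 4, 2.2-fold (0.35 log units) apart, within the scatter of two such steps. The change therefore carries across these two cores without a clear difference, but two pairs cannot show that it will behave alike on other cores in the series.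

As far as these compounds go, it remains open whether another group at that place, such as a nitrile or an amine, would shift the number on either core. The compounds shown also leave open which differences between the core of compound 1 and the core of compound 2 matter in this assay.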